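The source may report more compounds than this note shows. Statements on the series, on what has been measured and on what is new or still open speak of the compounds shown alone.

Compounds measured so far, in a physicochemical assay for solubility; a lower number here means a less soluble compound, a higher number a more soluble compound:

Compound 1 `CNC(=O)c1cc(C(=O)NC)c(=O)n(Cc2ccccc2)c1` — compound 1 gives >= 118 ug/mL, which is a limit of the assay and not a number.
Compound 2 `CNC(=O)c1ccc(=O)n(Cc2ccccc2)c1` — compound 2 gives >= 108 ug/mL, again a limit rather than a number.
Compound 3 `CNC(=O)c1cc(C(=O)NC2CC2)cn(CC2CCCOC2)c1=O` — compound 3 gives >= 131 ug/mL, also a limit.

Compound 1 therefore stands only at a limit in this assay, and the two other values shown are limits as well. Among the measured compounds shown here, the one measured step between compounds differing in a single place, hydrogen in place of methylcarbamoyl on an aromatic carbon, is a step that the two limits leave unreadable from compound 1 to compound 2; the two limits leave its size unreadable, as the lines the limit of >= 108 ug/mL in this assay, at which 1 of the 3 values shown sits, and the limit of >= 118 ug/mL in this assay, at which 1 of the 3 values shown sits, show. For the measured compounds named here, the third limit, (the limit of >= 131 ug/mL in this assay, at which 1 of the 3 values shown sits), belongs to compound 3 alone and bears on no step.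

Going by the values given here, the unmeasured compound 4 `CNC(=O)c1cc(C(=O)NC2CCC2)cn(Cc2ccccc2)c1=O` differs from compound 1 in a way no measured step covers: cyclobutyl in place of methyl on an amide-type nitrogen. Among the compounds with values here, no measured step gives a size for this change, so no direction can be expected with any confidence. The estimate for compound 4 in this assay is 100 ug/mL, between 30 ug/mL and 200 ug/mL. This estimated value means a step of an at least 1.1-fold lower number from compound 1 to compound 4 (0.07 log units; that floor lies within the scatter), expected to lie within the scatter.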

Compound 4, solubility: 28 ug/mL
The estimate for compound 4 lay 3.6-fold (0.55 log units) above the measured number; measured number below the stated range.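

In this assay, among the compounds shown here, cyclobutyl in place of methyl on an amide-type nitrogen is the first change in this set whose step can be read: an at least 4.2-fold lower number from compound 1 to compound 4 (0.62 log units; beyond the scatter). For the compounds shown here, the earlier compounds gave only limits, so they showed no direction for any change, whereas this one shows that the methylcarbamoyl to cyclobutylcarbamoyl change on the core of compound 1 lowers the number, and compound 4 is the first compound here with a number rather than a limit. The true size of the step may be larger than the printed floor, since compound 1 stands only at a limit of the assay and not at a number: the limit of >= 118 ug/mL in this assay, at which 1 of the 4 values shown sits.

Going by these compounds alone, whether any group larger than methyl on this nitrogen would lower the number, or whether the drop is particular to cyclobutyl, stays open; compound 3 carries a cyclopropyl on an amide-type nitrogen but differs from compound 1 in another place as well, so it gives no step for this question. Nothing shown tells how a longer chain, an amine or a carboxylic acid on this nitrogen would read in this assay.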